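The source may hold more compounds than are shown below. What is called first, only, known or untested is meant among the compounds shown, and "the series" means these compounds.

Measured compounds in an assay on HeLa cells for displacement of a labelled ligand from adenosine receptor A3 (Homo sapiens), read by radioligand binding, with a stated time of 180 min, tested at 1 uM; a lower number here means less inhibition, a higher number more inhibition at the concentration tested (going by the name of the read-out):
compound 1 `CC1=C(C(=O)OCC(F)(F)F)C(c2ccsc2)NC(=O)N1`: 1%
compound 2 `CC1=C(C(=O)OCC(F)(F)F)C(c2ccoc2)NC(=O)N1`: 1%
compound 3 `CC1=C(C(=O)OC(C(F)(F)F)C(F)(F)F)C(c2cccs2)NC(=O)N1`: 1%

Compound 3 stands level with compound 1 and compound 2 within the scatter; nearest is compound 1, furthest compound 2, and neither gap goes beyond the scatter. Compound 4 `CC1=C(C(=O)OCC(F)(F)F)C(c2cccs2)NC(=O)N1` follows from compound 3 by hydrogen in place of trifluoromethyl on a saturated chain carbon bound to an oxygen next to a carbonyl group and a saturated chain carbon. Among the measured compounds shown here, the only measured step, no change at the digits printed from compound 1 to compound 2 (within the scatter), swaps furan-3-yl for thiophen-3-yl and so does not touch the place that changes here; compound 1 and compound 3 differ in more than one place and both give the same read-out. With every measured compound at the same low level and no step beyond the scatter anywhere in the series, no movement beyond the scatter is expected in this assay. For compound 4 the estimate is 1% (range -10% to 12%), an expected step of no change at the digits printed from compound 3 to compound 4 (within the scatter).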

Compound 4, a percentage reported as inhibition, at one concentration (the size of the read-out at that concentration, not a potency): 1%
Compound 4: the middle estimate sits on the measured number at the digits printed; measured number inside the range.
By their numbers in this assay, from the lowest: compounds 1, 2, 3 and 4 (each within the scatter of the next).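

In this assay, among the compounds shown here, hydrogen in place of trifluoromethyl on a saturated chain carbon bound to an oxygen next to a carbonyl group and a saturated chain carbon gives no change at the digits printed from compound 3 to compound 4 (within the scatter), the first reading at this position. On the saturated ring carbon, thiophen-2-yl in place of furan-3-yl gives no change at the digits printed from compound 2 to compound 4 (within the scatter), and thiophen-2-yl in place of thiophen-3-yl gives no change at the digits printed from compound 1 to compound 4 (within the scatter), so neither place shows any response yet. With all four compounds at the same low level, these steps cannot rank the groups.

On these data alone, whether an amine, a carboxylic acid or a longer chain at the ester position would raise the read-out remains open. No supporting data explain the flat level.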